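Two Aminopyrimidine Anilines and a Hydroxy Analogue

The source may report more compounds than this note shows. Statements on the series, on what has been measured and on what is new or still open speak of the compounds shown alone.

Compounds measured so far:
compound 1, `CCc1ccc(Nc2cc(C)nc(N)n2)cc1`, > 180000 nM
compound 2, `Cc1ccc(-c2cc(Cl)cc(Nc3cc(C)nc(N)n3)c2)cc1`, > 63000 nM

Both compounds were tested in an assay on cells for inhibition of S-adenosylmethionine decarboxylase proenzyme (Homo sapiens), read by mass spectrometry, at pH 7.2; on this read-out higher numbers stand for weaker inhibition and lower numbers for stronger inhibition. For compound 1 the result is only a limit, given as > 180000 nM, as the limit of > 180000 nM in this assay, at which 1 of the 2 values shown sits, records. For compound 2 the result is likewise only a limit, > 63000 nM, as recorded by the limit of > 63000 nM in this assay, at which 1 of the 2 values shown sits. Within the data shown here, no numerical value therefore exists for compound 2, and no step between measured compounds can be quantified; the two results show only that neither compound reached measurable inhibition within the tested range.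

Compound 3, `Cc1cc(Nc2cc(Cl)cc(-c3ccc(O)cc3)c2)nc(N)n1`, has not yet been measured. It differs from compound 2 by hydroxy in place of methyl on an aromatic carbon, para to a large group. Among the measured compounds shown here, with no measured step to draw on, and with compound 2 sitting at a limit, the step in this assay is expected to be small, in no clear direction, and most likely not beyond the scatter. Compound 3 is therefore expected to give about 100000 nM, within 30000 nM to 300000 nM, and the expected step from compound 2 to compound 3 is a step that the limit leaves unreadable from compound 2 to compound 3.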

Compound 3, half-maximal inhibitory concentration: > 180000 nM
Compound 3: no number, only a limit; the forecaster's own chance of this, stated with the estimate: 80%; middle value at least 1.8-fold (0.25 log units) from the limit.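

In this assay, compound 2 and compound 3 are both recorded only as limits, so no step can be read between them and the change from 4-methylphenyl to 4-hydroxyphenyl cannot be given a size. The compounds shown leave open whether any close relative of these three gives a measurable value in this assay.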